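The source may report more compounds than this note shows. Statements on the series, on what has been measured and on what is new or still open speak of the compounds shown alone.

Measured compounds in the series:
Compound 1, `O=C(NCc1ccc(OCc2ccccc2)cc1)n1cccn1`: "not determined" (no result reported).
Compound 2, `Cc1cnn(C(=O)N2CCN(C(c3ccc(OCc4ccccc4)cc3)c3ccc(OCc4ccccc4)cc3)CC2)c1`: > 100000 nM.
Compound 3, `O=C(N1CCN(C(c2ccc(OCc3ccccc3)cc2)c2ccc(OCc3ccccc3)cc2)CC1)n1cccn1`: > 100000 nM.

In an assay on membranes from brain for binding affinity to Monoacylglycerol lipase ABHD6 (Mus musculus), read by fluorescence, with stated times of 1 h and 30 min (a lower number here means a stronger inhibitor, a higher number a weaker inhibitor), compound 3 gives no number, only the assay limit > 100000 nM. Compound 2 likewise sits at the limit > 100000 nM. Compound 1 has no result in this assay. Among the measured compounds shown here, the single step between measured compounds, a step that the two limits leave unreadable from compound 2 to compound 3, is therefore unreadable: both ends rest at the limit. For the measured compounds named here, the one piece of evidence on the numbers is the limit of > 100000 nM in this assay, at which 2 of the 3 values shown sit, which says only that neither measured compound reaches a readable inhibition.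

Compound 4, `N#Cc1cnn(C(=O)N2CCN(C(c3ccc(OCc4ccccc4)cc3)c3ccc(OCc4ccccc4)cc3)CC2)c1`, differs from compound 3 by cyano in place of hydrogen on an aromatic carbon. Going by the values given here, no measured step bears on this change, since the only step cannot be sized. The expectation therefore rests on compound 3 alone, whose limit > 100000 nM gives no anchor for an improvement. Compound 4 is expected to stay at or near the limit, the step of an at least 2.0-fold lower number from compound 3 to compound 4 (0.30 log units; that floor lies within the scatter) being an estimate without support from measured steps. The estimate for compound 4 in this assay is 50000 nM, with a range from 2000 nM to 300000 nM.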

Compound 4, half-maximal inhibitory concentration: 130000 nM
The estimate for compound 4 lay 2.6-fold (0.41 log units) below the measured number; the measured number falls inside the stated range.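

In this assay, the steps to compound 4 from compound 3 and from compound 2 cannot be read, since each of those two partners gives only a limit: the limit of > 100000 nM in this assay, at which 2 of the 4 values shown sit. The compounds shown leave open how hydrogen, methyl and cyano at this place compare in this assay.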